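The source may hold more compounds than are shown below. What is called first, only, known or untested is meant among the compounds shown, and "the series" means these compounds.

For the measured compounds named here, in a functional assay on SF-295 cells (Homo sapiens) for antiproliferative activity, read by sulforhodamine B assay, with a stated time of 72 h (on this read-out higher numbers stand for weaker inhibition and lower numbers for stronger inhibition), compound 1 `Cc1cc(C)nc(NS(=O)(=O)c2ccc(Nc3nncc4ccccc34)cc2)n1` gives 0.56 nM and compound 2 `Clc1ccc(C(/C=C/c2ccccc2)=N\Nc2nncc3ccccc23)cc1` gives 0.53 nM, so compound 1 stands within the scatter of the only other measured compound. Compound 3 `NS(=O)(=O)c1ccc(Nc2nncc3ccccc23)cc1` has yet to be measured. It differs from compound 1 in one place: hydrogen in place of 4,6-dimethylpyrimidin-2-yl on a sulfonamide nitrogen, which means hydrogen in place of 4,6-dimethylpyrimidin-2-yl on a sulfonamide nitrogen. Going by the values given here, no two measured compounds differ in a single place, so no measured step guides the expectation. With so large a group gone, a moderate rise in the number in this assay is expected, meaning weaker inhibition, although a result within the scatter remains possible. The estimated change is a 2.7-fold higher number from compound 1 to compound 3 (0.43 log units; beyond the scatter). For compound 3 the expected value is 1.5 nM, with an estimated range from 0.3 nM to 10 nM.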

Compound 3, half-maximal inhibitory concentration: 5.3 nM
Beside the measured number, compound 3's estimate is 3.5-fold (0.55 log units) below it, and the stated range covers the measured number.
By their numbers in this assay, from the lowest: compounds 2 and 1 (each within the scatter of the next); then compound 3.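

Removing the 4,6-dimethylpyrimidin-2-yl group from the sulfonamide nitrogen gives a step in this assay of a 9.5-fold higher number from compound 1 to compound 3 (0.98 log units; beyond the scatter), so this position does respond to what it carries. Without the group, compound 3 still gives 5.3 nM, which shows that the group adds to the activity of the shared core but does not carry all of it. Nothing available explains the size of this step.

The compounds shown leave open whether a smaller group on that nitrogen, such as methyl or acetyl, or another ring, such as phenyl or pyridin-2-yl, would bring the number back towards that of compound 1, 0.56 nM. They also leave open whether the step belongs to the pyrimidine ring itself or to its two methyl groups.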